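Bromo for methoxy on the pendant phenyl ring

The source may hold more compounds than are shown below. What is called first, only, known or untested is meant among the compounds shown, and "the series" means these compounds.

Of the compounds shown here, three sharing one core have been measured in a functional assay on KM12 cells (Homo sapiens) for inhibition, read by sulforhodamine B assay, with a stated time of 48 h, tested at 10 uM; a higher number here means more inhibition at the concentration tested (going by the name of the read-out), a lower number less inhibition. Compound 1 `Brc1cn2ccnc2c(-c2ccc3ncn(C4CCCCC4)c3c2)n1` gives 67.7%, compound 2 `COc1ccc(-c2cn3ccnc3c(-c3ccc4ncn(C5CCCCC5)c4c3)n2)cc1` gives 83.2%, and compound 3 `Clc1ccc(-c2cn3ccnc3c(-c3ccc4ncn(C5CCCCC5)c4c3)n2)cc1` gives 10.6%. Compound 2 stands highest of the three: the step of a number 15.5 percentage points higher from compound 1 to compound 2 (beyond the scatter) is modest, whereas a number 72.6 percentage points lower from compound 2 to compound 3 (beyond the scatter) and a number 57.1 percentage points lower from compound 1 to compound 3 (beyond the scatter) are both large drops.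

Compound 4 `Brc1ccc(-c2cn3ccnc3c(-c3ccc4ncn(C5CCCCC5)c4c3)n2)cc1` has not yet been measured in this assay. Its difference from compound 2 is bromo in place of methoxy on an aromatic carbon. The step that bears most directly on it is a number 72.6 percentage points lower from compound 2 to compound 3 (beyond the scatter), where replacing methoxy with chloro at the same position cost most of the inhibition; a number 57.1 percentage points lower from compound 1 to compound 3 (beyond the scatter) points the same way. Bromo at that position has no precedent among the measured compounds, so the expectation rests on chloro alone, and a large downward step is expected, a number 58.2 percentage points lower from compound 2 to compound 4 (beyond the scatter). Compound 4 is therefore estimated at 25%, with a range from 5% to 60%.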

Compound 4, a percentage reported as inhibition, at one concentration (the size of the read-out at that concentration, not a potency): 23.3%
Compound 4: middle estimate off by 1.7 percentage points, on the high side; low and high end bracket the measured number.
By their numbers in this assay, from the lowest: compound 3; then compound 4; then compound 1; then compound 2.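

In this assay the loss seen with chloro proves not to be peculiar to chloro, as bromo on the same aromatic carbon also gives a number 59.9 percentage points lower from compound 2 to compound 4 (beyond the scatter) and both halogens now stand far under methoxy at this position. The two halogens do not read the same, though, with a number 12.7 percentage points higher from compound 3 to compound 4 (beyond the scatter) as a modest step beyond the scatter. Putting 4-bromophenyl in place of the bromo on the shared core also costs inhibition, at a number 44.4 percentage points lower from compound 1 to compound 4 (beyond the scatter), which leaves 4-methoxyphenyl as the only one of the three phenyl groups shown that gains over bromo.

No evidence at hand says why these groups differ so widely. Going by these compounds, whether an amine, a hydroxyl or an ethoxy group at this position would hold the level of methoxy stays open.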